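The compounds below may be only part of what the source reports. "The series", "measured", "known", "first", "only" and "open" are said of these compounds alone.

In an assay on HeLa cells for inhibition of Indoleamine 2,3-dioxygenase 1 (Homo sapiens), read by spectrophotometry, with a stated time of 24 h (on this read-out higher numbers stand for an effect only at larger amounts of compound and lower numbers for an effect already at smaller amounts), compound 1 `NNc1nonc1/C(=N/O)Nc1ccc(F)c(Br)c1` gives 556 nM, and compound 2 `N=S1(=O)CC(Nc2nonc2/C(=N/O)Nc2ccc(F)c(Br)c2)C1` gives 53 nM, the lowest of the two numbers. Within the data shown here, the single measured step, a 10-fold lower number from compound 1 to compound 2 (1.02 log units; beyond the scatter), shows that what sits on this ring nitrogen matters strongly. Compound 3 `NS(=O)(=O)CCNc1nonc1/C(=N/O)Nc1ccc(F)c(Br)c1` differs from compound 2 by a group of 6 heavy atoms (2 carbon, 1 nitrogen, 2 oxygen, 1 sulfur; no ring) in place of a group of 6 heavy atoms (3 carbon, 1 nitrogen, 1 oxygen, 1 sulfur; one four-membered non-aromatic ring with 1 hetero atom), on a nitrogen on an aromatic ring. Among the measured compounds shown here, no measured step covers a swap between two groups of equal size at this place, so the chemist expects a 1.5-fold higher number from compound 2 to compound 3 (0.18 log units; within the scatter), a change not clearly beyond the scatter. For compound 3 the chemist estimates 80 nM in this assay, within a range of 25 nM to 250 nM.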

Compound 3, half-maximal effective concentration: 11 nM
For compound 3 the middle estimate is 7.3-fold (0.86 log units) above the measured one, outside the stated range (below it).
By their numbers in this assay, from the lowest: compound 3; then compound 2; then compound 1.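

At this nitrogen on an aromatic ring, groups of equal heavy-atom count are not interchangeable: in this assay, replacing the four-membered ring group with 2-sulfamoylethyl gives a 4.8-fold lower number from compound 2 to compound 3 (0.68 log units; beyond the scatter). A ring is therefore not required for a low number here, and against the amino group the open chain gives a 51-fold lower number from compound 1 to compound 3 (1.70 log units; beyond the scatter). No evidence on hand explains this difference.

Compound 3 changes the ring and the sulfur group together, so their separate contributions remain unresolved. On these data alone, whether a longer sulfamoyl chain or a carboxylic acid on the ethyl chain would keep the number this low also remains open.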